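Benzoxazole sulfonamide series: tolerance on human kidney cells

The compounds below may be only part of what the source reports. "The series", "measured", "known", "first", "only" and "open" are said of these compounds alone.

Measured so far:
compound 1 `Cc1ccc(S(=O)(=O)Nc2ccc3oc(-c4ccccc4)nc3c2)cc1` — 75000 nM
compound 2 `O=S(=O)(Nc1ccc(-c2nc3ccccc3o2)cc1)c1ccc(F)c(C(F)(F)F)c1` — 82000 nM
compound 3 `O=S(=O)(Nc1ccc2oc(-c3ccccc3)nc2c1)c1ccc(Cl)c(C(F)(F)F)c1` — 66000 nM

In an ADME assay on HEK293 cells (Homo sapiens) for cytotoxicity, read by resazurin assay, with a stated time of 48 h (a higher number here means that more compound is tolerated, a lower number that less compound is tolerated), the three numbers lie within the scatter of one another. Compound 1 sits within the scatter of compound 2 and of compound 3, so nothing separates it from either on these data. Compound 4 `O=S(=O)(Nc1ccc2oc(-c3ccccc3)nc2c1)c1cccc(O)c1` carries a single change from compound 1: 3-hydroxyphenyl in place of 4-methylphenyl on a sulfonyl sulfur. Going by the values given here, no step between two measured compounds of this kind is available, so the expectation rests on the flat picture across compound 1, compound 2 and compound 3 alone. For compound 4 no step beyond the scatter is expected in this assay, in either direction. Compound 4 is estimated at 75000 nM, with a range of 40000 nM to 140000 nM, which means an expected step of no change at the digits printed from compound 1 to compound 4 (within the scatter).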

Compound 4, half-maximal cytotoxic concentration: > 100000 nM
Compound 4 gave a limit, no number; the forecaster's own chance of this, stated with the estimate: 20%; middle value at least 1.3-fold (0.12 log units) away from the limit.
By their numbers in this assay, from the lowest: compounds 3, 1 and 2 (each within the scatter of the next). At a limit, above all of these: compound 4.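

In this assay compound 4 gave a limit of the assay and not a number: the limit of > 100000 nM in this assay, at which 1 of the 4 values shown sits.

Going by these compounds alone, the single change on a sulfonyl sulfur, 3-hydroxyphenyl in place of 4-methylphenyl, gives the first readable step, an at least 1.3-fold higher number from compound 1 to compound 4 (0.12 log units; that floor lies within the scatter). A hydrogen-bond donor and acceptor therefore enter at this place with no lower number seen, although the floor of that step does not separate the two compounds.

Open, from the compounds shown here alone, is how far compound 4 lies past the limit. Also open, going by these compounds, is whether an amine or a carboxylic acid on the same phenyl ring would be tolerated in the same way.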